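Benzyl substituent swap on the shared core

The source may hold more compounds than are shown below. What is called first, only, known or untested is meant among the compounds shown, and "the series" means these compounds.

Measured so far:
compound 1 `Cc1ccccc1CN1CCc2c(sc(NC(=O)c3ccccc3Cl)c2C(N)=O)C1`: > 50000 nM
compound 2 `N#Cc1ccccc1CN1CCc2c(sc(NC(=O)c3ccccc3Cl)c2C(N)=O)C1`: 10400 nM
compound 3 `NC(=O)c1c(NC(=O)c2ccccc2Cl)sc2c1CCN(Cc1ccccc1F)C2`: 21800 nM

In a functional assay on HL-60 cells (Homo sapiens) for antiproliferative activity, with a stated time of 24 h (on this read-out higher numbers stand for weaker inhibition and lower numbers for stronger inhibition), compound 1 gives > 50000 nM, which is a limit of the assay and not a number. Compound 2 gives 10400 nM and compound 3 gives 21800 nM. Among the two numbers compound 3 stands highest; its nearest neighbour is compound 2, with a 2.1-fold higher number from compound 2 to compound 3 (0.32 log units; beyond the scatter).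

Compound 4 `NC(=O)c1c(NC(=O)c2ccccc2Cl)sc2c1CCN(Cc1ccc([N+](=O)[O-])cc1)C2` is not yet measured. It differs from compound 3 by 4-nitrophenyl in place of 2-fluorophenyl on a saturated chain carbon bound to an amine nitrogen in a ring. Among the measured compounds shown here, no measured step swaps this same pair of groups. For the measured compounds named here, the steps that bear on it all change the group on that same saturated chain carbon: an at least 4.8-fold lower number from compound 1 to compound 2 (0.68 log units; beyond the scatter), an at least 2.2-fold lower number from compound 1 to compound 3 (0.36 log units; beyond the scatter) and a 2.1-fold higher number from compound 2 to compound 3 (0.32 log units; beyond the scatter). Compound 1, which carries methyl at that place, sits at the limit of > 50000 nM in this assay, at which 1 of the 3 values shown sits. Both cyano and fluoro in place of methyl gave lower numbers, and cyano gave a lower number than fluoro. For compound 4 a modest downward step in this assay is therefore expected, about a 1.8-fold lower number from compound 3 to compound 4 (0.26 log units; within the scatter), bringing it near compound 2. For compound 4 the estimate in this assay is 12000 nM, with a range from 4000 nM to 40000 nM.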

Compound 4, half-maximal inhibitory concentration: 11400 nM
For compound 4 the middle estimate is 1.1-fold (0.02 log units) above the measured one; measured number inside the range.
By their numbers in this assay, from the lowest: compounds 2, 4 and 3 (each within the scatter of the next, the first and the last beyond it). At a limit, above all of these: compound 1.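

Among the compounds shown here, compound 4 is the first in the set with a group other than a 2-substituted phenyl at this place, and the change still leaves activity measurable in this assay: a 1.9-fold lower number from compound 3 to compound 4 (0.28 log units; within the scatter) and a 1.1-fold higher number from compound 2 to compound 4 (0.04 log units; within the scatter), so 4-nitrophenyl cannot be told apart from either 2-fluorophenyl or 2-cyanophenyl. For the compounds shown here, the gap beyond the scatter stays with 2-methylphenyl, since the step to 4-nitrophenyl shows an at least 4.3-fold lower number from compound 1 to compound 4 (0.64 log units; beyond the scatter), which makes compound 1 the only compound that stands apart from the rest of the set. Compound 1 gives a limit of the assay and not a number, so the size of that step stays open-ended: the limit of > 50000 nM in this assay, at which 1 of the 4 values shown sits.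

The step from 2-fluorophenyl to 4-nitrophenyl changes both the group and its place on the phenyl ring, so 2-nitrophenyl and 4-fluorophenyl would be needed to separate the two changes. From the compounds shown here alone, whether a group of another kind, such as 4-aminophenyl or a phenyl ring carrying a carboxylic acid, gives a number well below that of compound 2, 10400 nM, remains open.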